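Stereoisomer Step from Compound 2 to Compound 4

The compounds below may be only part of what the source reports. "The series", "measured", "known", "first", "only" and "open" are said of these compounds alone.

Compound 2 `O=C(O)[C@@H](CO)NC(=O)[C@H]1C[C@H](O)CN1` was examined in an ADME assay on Caco-2 cells (Homo sapiens) for metabolic stability, read by HPLC, with a stated time of 12 h; a higher number here means that the compound lasts longer, a lower number that the compound disappears faster. There compound 2 sits at > 12 h, which is a limit of the measurement and not a number. Compound 1 `O=C(O)[C@H](CO)NC(=O)[C@H]1C[C@H](O)CN1` likewise sits at the limit > 12 h. Compound 3 `O=C(O)[C@H](CO)NC(=O)[C@H]1C[C@@H](O)CN1` also sits at the limit > 12 h. The three steps among them, a step that the two limits leave unreadable from compound 1 to compound 2, a step that the two limits leave unreadable from compound 1 to compound 3 and a step that the two limits leave unreadable from compound 2 to compound 3, cannot be read because of the limit of > 12 h in this assay, at which 3 of the 3 values shown sit. Compound 4 `O=C(O)[C@H](CO)NC(=O)[C@@H]1C[C@H](O)CN1` differs from compound 2 as follows: the two compounds have the same atoms and bonds and differ only in configuration as drawn: 2 of 3 stereo elements differ; a stereocentre at a saturated chain carbon is drawn R in compound 2 and S in compound 4; a stereocentre at a saturated ring carbon is drawn R in compound 2 and S in compound 4. Among the measured compounds shown here, the steps that bear on it are those same unreadable ones, so no direction beyond the scatter can be foreseen in this assay. Compound 4 is therefore expected to give 14 h, within 8 h to 30 h. The expected step that the limit leaves unreadable from compound 2 to compound 4 is thus essentially none.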

Compound 4, half-life: > 12 h
Compound 4 gave a limit, no number; the forecaster's own chance of this, stated with the estimate: 85%; the middle value does not contradict the limit.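

The steps from compound 4 to compounds 1, 2 and 3 cannot be read in this assay: the limit of > 12 h in this assay, at which 4 of the 4 values shown sit.

The compounds shown leave open whether configuration at any of these stereocentres affects the half-life in this assay at all.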